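N-substituent variation on the shared core: cyclopropyl to cyclohexyl

This account rests on a few compounds, and the source may have more. Where it says the series, first, only, none or still open, it means among the compounds named here.

Measured compounds:
- compound 1 `CC(C)c1onc(-c2c(Cl)cccc2Cl)c1COc1ccc(-c2nc3ccc(C(=O)O)cc3n2C)cc1`: 7150 nM
- compound 2 `CC(C)c1onc(-c2c(Cl)cccc2Cl)c1COc1ccc(-c2nc3ccc(C(=O)O)cc3n2Cc2ccc(F)cc2)cc1`: 1140 nM
- compound 3 `CC(C)c1onc(-c2c(Cl)cccc2Cl)c1COc1ccc(-c2nc3ccc(C(=O)O)cc3n2CC2CC2)cc1`: 2650 nM

All three share one core and differ only in the group on a saturated chain carbon bound to an aromatic nitrogen. In an assay on HEK-293T cells for antagonist activity at vitamin D3 receptor (Homo sapiens), read by a luciferase reporter, with a stated time of 24 h (a lower number here means a stronger inhibitor, a higher number a weaker inhibitor), compound 1 carries hydrogen there and gives the weakest number of the set. Compound 3, with cyclopropyl, stands second highest of the three numbers: it sits between compound 1 and compound 2, with a 2.7-fold lower number from compound 1 to compound 3 (0.43 log units; beyond the scatter) and a 2.3-fold higher number from compound 2 to compound 3 (0.37 log units; beyond the scatter).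

Compound 4 `CC(C)c1onc(-c2c(Cl)cccc2Cl)c1COc1ccc(-c2nc3ccc(C(=O)O)cc3n2CC2CCCCC2)cc1` has not been measured. Its change from compound 3 is cyclohexyl in place of cyclopropyl on a saturated chain carbon bound to an aromatic nitrogen. Among the measured compounds shown here, two measured steps bear on it. Enlarging the substituent from hydrogen gave a 6.3-fold lower number from compound 1 to compound 2 (0.80 log units; beyond the scatter) and a 2.7-fold lower number from compound 1 to compound 3 (0.43 log units; beyond the scatter), both lowering the number; the further enlargement from cyclopropyl to cyclohexyl is of the same kind but smaller in relative terms, so a modest step in the same direction is expected, roughly toward the level of compound 2, though a step within the scatter cannot be excluded.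

For compound 4 the estimate in this assay is 1500 nM, with a range of 600 nM to 4000 nM, corresponding to an expected step of a 1.8-fold lower number from compound 3 to compound 4 (0.25 log units; within the scatter).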

Compound 4, half-maximal inhibitory concentration: 346 nM
Compound 4: the middle estimate sits 4.3-fold (0.64 log units) above what was measured; the whole stated range lies above it.
By their numbers in this assay, from the lowest: compound 4; then compound 2; then compound 3; then compound 1.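

In this assay the change from cyclopropyl to cyclohexyl gives a 7.7-fold lower number from compound 3 to compound 4 (0.88 log units; beyond the scatter), showing that this position still responds strongly once a small saturated ring is in place. An aromatic ring is not needed for the lowest number in this set: cyclohexyl in place of 4-fluorophenyl gives a 3.3-fold lower number from compound 2 to compound 4 (0.52 log units; beyond the scatter), and compound 2 no longer holds the lowest number. Among the compounds shown here, measured against hydrogen, cyclohexyl gives a 21-fold lower number from compound 1 to compound 4 (1.32 log units; beyond the scatter), the only step at this position graded large, and the four compounds now run from lowest to highest number as cyclohexyl, 4-fluorophenyl, cyclopropyl and hydrogen. Nothing available on these compounds accounts for the size of these steps.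

Open, as far as these compounds go, is whether the trend continues with a cycloheptyl ring or an open chain such as n-hexyl, and whether a piperidine or tetrahydropyran ring can stand in place of cyclohexyl. Also open, from the compounds shown here alone, is what plain phenyl would give at this position, which would separate the ring itself from the fluorine of compound 2.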